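The source may hold more compounds than are shown below. What is called first, only, known or untested is meant among the compounds shown, and "the series" means these compounds.

Compound 1 `CCCN(c1ccc(OC)cc1)c1ncnc2occ(C)c12` gives 33.8 nM
Compound 2 `CSc1ccc(N(C)c2ncnc3occ(C)c23)cc1` gives 15.7 nM

In a functional assay on HeLa cells (Homo sapiens) for antiproliferative activity, read by sulforhodamine B assay, with a stated time of 48 h (on this read-out lower numbers stand for stronger inhibition and higher numbers for weaker inhibition), compound 1 gives 33.8 nM and so holds the higher of the two numbers, the weaker result of the pair. Compound 2 sits at 15.7 nM with a gap to compound 1 that lies beyond the usual scatter. These two compounds differ in more than one place, so the gap cannot be pinned on any single change.

Compound 3 `CCN(c1ccc(OC)cc1)c1ncnc2occ(C)c12` departs from compound 1 in one place only, and the difference reads hydrogen in place of methyl on a saturated chain carbon, two bonds along the chain from a nitrogen on an aromatic ring in full: hydrogen in place of methyl on a saturated chain carbon, two bonds along the chain from a nitrogen on an aromatic ring. Propyl thus becomes ethyl. Within the data shown here, no measured step covers this change, so only a small move toward a lower number in this assay is expected, possibly not beyond the scatter. The direction is a tentative call resting on compound 2 at 15.7 nM which reads lower with a different set of groups. In numbers, the expected step is a 1.5-fold lower number from compound 1 to compound 3 (0.19 log units; within the scatter) at this stage. The estimated value for compound 3 is 22 nM with 8 nM to 60 nM as its expected range.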

Compound 3, half-maximal inhibitory concentration: 15.8 nM
Estimate against measurement, compound 3: 1.4-fold (0.14 log units) above; low and high end bracket the measured number.
By their numbers in this assay, from the lowest: compounds 2 and 3 (each within the scatter of the next); then compound 1.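

Among these compounds, for the first time a gap can be pinned on a single change: in this assay, putting hydrogen in place of methyl on a saturated chain carbon, two bonds along the chain from a nitrogen on an aromatic ring, gives a 2.1-fold lower number from compound 1 to compound 3 (0.33 log units; beyond the scatter) while the rest of the molecule stays the same. The step is modest but lies beyond the usual scatter, so going from propyl to ethyl at this place does register in the read-out, and the end methyl of the propyl chain is not needed to reach this level of activity. Nothing given here accounts for why the shorter chain reads lower.

A single step on one chain shows a direction between two lengths and no more, so the compounds shown do not say whether a longer butyl chain would continue the trend in reverse or how a branched isopropyl group would read. They also leave open how the same position would respond to a chain ending in an amine or a hydroxyl group.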